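The source may hold more compounds than are shown below. What is called first, only, known or untested is meant among the compounds shown, and "the series" means these compounds.

Three compounds have been measured in a functional assay on DU-145 cells (Homo sapiens) for cytotoxicity, read by sulforhodamine B assay, with a stated time of 2 days, tested at 100 uM; a higher number here means more inhibition at the concentration tested (going by the name of the read-out), a lower number less inhibition:

compound 1 `CCCc1n[nH]c2c(=O)n(NC(=O)c3ccncc3)c(-c3cccc(OC)c3)nc12`, 9.13%
compound 2 `O=C(Nn1c(-c2cccc([N+](=O)[O-])c2)nc2c(-c3ccc(F)cc3)n[nH]c2c1=O)c1cccnc1`, 24.9%
compound 3 `COc1cccc(-c2nc3c(-c4ccc(C5CCNCC5)cc4)n[nH]c3c(=O)n2NC(=O)c2ccncc2)c1`, 37%

Compound 2 stands second of the three, beyond the scatter below compound 3 and beyond the scatter above compound 1. Among the compounds with values here, the only measured one-place step runs from compound 1 to compound 3, a number 27.9 percentage points higher from compound 1 to compound 3 (beyond the scatter), with 4-(piperidin-4-yl)phenyl in place of propyl on an aromatic carbon. Compound 4 `O=C(Nn1c(-c2cccc([N+](=O)[O-])c2)nc2c(CCc3ccccc3)n[nH]c2c1=O)c1cccnc1` differs from compound 2 by a swap of the group on an aromatic carbon: phenethyl in place of 4-fluorophenyl on an aromatic carbon. Both the leaving and the entering group hold one six-membered aromatic ring of carbon only, so that earlier step is only a loose guide. Since compound 2 gives 24.9% and the step of a number 27.9 percentage points higher from compound 1 to compound 3 (beyond the scatter) concerns other groups, only a small change is expected, a number 0.1 percentage points higher from compound 2 to compound 4 (within the scatter). Compound 4 is estimated at 25%, between 10% and 40%.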

Compound 4, a percentage reported as inhibition, at one concentration (the size of the read-out at that concentration, not a potency): 22.5%
Beside the measured number, compound 4's estimate is 2.5 percentage points above it; low and high end bracket the measured number.
By their numbers in this assay, from the lowest: compound 1; then compounds 4 and 2 (each within the scatter of the next); then compound 3.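

In this assay, the aromatic carbon of the five-membered ring takes phenethyl in place of 4-fluorophenyl with a number 2.4 percentage points lower from compound 2 to compound 4 (within the scatter) and no real change in the read-out. Both groups hold one six-membered aromatic ring of carbon only, so swapping one for the other at this position leaves the number where it was, at least in this pair. Nothing measured here explains why the two read alike. Still open, on these data alone, is whether a longer chain joining that ring to the core, or a carboxylic acid on the ring, would shift the number beyond the usual scatter.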